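A few compounds are considered here, and "the series" means these few. Any claim that something is new, unique, unknown or untested is made for them only; others in the source may bear on it.

In an ADME assay on H9c2 cells (Rattus norvegicus) for cytotoxicity (a higher number here means a weaker inhibitor, a lower number a stronger inhibitor), compound 1 (`CCc1ccc2nc(NC(=O)C3CC3)sc2c1`) gives > 50000 nM, a limit of the assay. Compound 2 (`O=C(Nc1nc2ccc(F)cc2s1)C1CC1`) gives > 50000 nM, also a limit. Compound 3 (`O=C(Nc1nc2ccc(C(F)(F)F)cc2s1)C1CC1`) gives > 50000 nM, again a limit and not a number. Compound 3 therefore stands at the limit of > 50000 nM in this assay, at which 3 of the 3 values shown sit. Compound 4 (`FC(F)(F)c1ccc2nc(N/N=C/C3CC3)sc2c1`) differs from compound 3 as follows: a group of 5 heavy atoms (4 carbon, 1 nitrogen; one three-membered non-aromatic ring of carbon only) in place of a group of 5 heavy atoms (4 carbon, 1 oxygen; one three-membered non-aromatic ring of carbon only), on a nitrogen on an aromatic ring. The measured steps are a step that the two limits leave unreadable from compound 1 to compound 2, a step that the two limits leave unreadable from compound 1 to compound 3 and a step that the two limits leave unreadable from compound 2 to compound 3. All three are changes on an aromatic carbon, and none touches the group on a nitrogen. With no readable step to lean on, only a small move toward stronger inhibition in this assay is expected, an estimated at least 1.2-fold lower number from compound 3 to compound 4 (0.09 log units; that floor lies within the scatter). Compound 4 is expected at 40000 nM, with an estimated range of 10000 nM to 100000 nM.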

Compound 4, half-maximal inhibitory concentration: 13000 nM
For compound 4 the middle estimate is 3.1-fold (0.49 log units) above the measured one; the range from low to high includes it.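

Among the compounds shown here, compound 4 gives the first readable step in this assay, and it comes from the group on the nitrogen on an aromatic ring: an at least 3.8-fold lower number from compound 3 to compound 4 (0.58 log units; beyond the scatter). Cyclopropylcarbonyl gives way here to a group with the same heavy-atom count, nitrogen in place of oxygen, and the cyclopropane ring kept. The steps among compound 1, compound 2 and compound 3 cannot be read, and the limit remains the most common result: the limit of > 50000 nM in this assay, at which 3 of the 4 values shown sit.

As far as these compounds go, whether this exchange gives a similar step with ethyl or fluoro on the core remains open. So does the outcome with a longer chain or an amine in place of the cyclopropane ring.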